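Fluorophenyl for Cyanophenyl on the Triazole Benzyl Arm

A few compounds are considered here, and "the series" means these few. Any claim that something is new, unique, unknown or untested is made for them only; others in the source may bear on it.

Measured so far:
compound 1 `Cc1cc(C)c(Oc2cc(Nc3ccc(C#N)cc3)ncc2C(=O)NCc2cn(Cc3cccc(Cl)c3)nn2)c(C)c1` gives 187000 nM in an ADME assay on MT4 cells (Homo sapiens) for cytotoxicity, read by MTT assay, with a stated time of 5 days; a higher number here means that more compound is tolerated, a lower number that less compound is tolerated.
compound 2 `Cc1cc(C)c(Oc2cc(Nc3ccc(C#N)cc3)ncc2C(=O)NCc2cn(CC(N)=O)nn2)c(C)c1` gives 24000 nM in this assay.
compound 3 `Cc1cc(C)c(Oc2cc(Nc3ccc(C#N)cc3)ncc2C(=O)NCc2cn(Cc3ccccc3C#N)nn2)c(C)c1` gives > 219000 nM in this assay, which is a limit of the assay and not a number.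

Compound 3 therefore stands at the top of the three shown, with only a limit known for it (the limit of > 219000 nM in this assay, at which 1 of the 3 values shown sits). Compound 4 `Cc1cc(C)c(Oc2cc(Nc3ccc(C#N)cc3)ncc2C(=O)NCc2cn(Cc3ccc(F)cc3)nn2)c(C)c1` differs from it in one place: 4-fluorophenyl in place of 2-cyanophenyl on a saturated chain carbon bound to an aromatic nitrogen. Within the data shown here, two measured steps bear on this change. The move between the two aryl-bearing compounds, an at least 1.1-fold higher number from compound 1 to compound 3 (0.06 log units; that floor lies within the scatter), lies within the scatter, whereas the move from the carbamoyl compound, an at least 9.1-fold higher number from compound 2 to compound 3 (0.96 log units; beyond the scatter), is the one that stands apart. Since compound 4 keeps an aryl group at this position, the step is expected to be small, an at least 1.0-fold lower number from compound 3 to compound 4 (0.03 log units; that floor lies within the scatter), with a fair chance that the assay again reports only a limit. For compound 4 the value in this assay is estimated at 200000 nM, with a range from 90000 nM to 300000 nM.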

Compound 4, half-maximal cytotoxic concentration: >= 153000 nM
Compound 4: a limit, no number; the forecaster's own chance of this, stated with the estimate: 50%; the middle value does not contradict the limit.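

At the position on a saturated chain carbon bound to an aromatic nitrogen, a third aryl group, 4-fluorophenyl, now stands in the series, and in this assay compound 4 is reported only as a limit, not a number: the limit of >= 153000 nM in this assay, at which 1 of the 4 values shown sits.

Among these compounds, the one step that can be read is an at least 6.3-fold higher number from compound 2 to compound 4 (0.80 log units; beyond the scatter), so the gap from the carbamoyl compound seen with 3-chlorophenyl and 2-cyanophenyl also appears with an aryl group that carries fluorine and no nitrile. The steps to compound 4 from compound 1 and from compound 3 cannot be read, so the change from 2-cyanobenzyl to 4-fluorobenzyl has no size here.

Going by these compounds, the order among the three aryl compounds remains open. On these data alone, it is also open whether a benzyl arm carrying an amine or a carboxylic acid, or a longer alkyl chain in place of the ring, would stay with them or move toward compound 2.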